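The source may hold more compounds than are shown below. What is called first, only, known or untested is meant among the compounds shown, and "the series" means these compounds.

Compound 1 `Cc1ccc([S+]([O-])c2cccc(N)c2C#N)cc1` was examined in a functional assay on MT4 cells (Homo sapiens) for cytotoxicity; a higher number here means a weaker inhibitor, a lower number a stronger inhibitor. In this assay compound 1 gives > 200000 nM, which is a limit of the assay rather than a number. Compound 2 `N#Cc1c(N)cccc1[S+]([O-])c1ccc(Br)cc1` differs from compound 1 by bromo in place of methyl on an aromatic carbon. In this assay compound 2 gives > 200000 nM, again a limit. The size of the step is therefore a step that the two limits leave unreadable from compound 1 to compound 2, because of the limit of > 200000 nM in this assay, at which 3 of the 3 values shown sit. Compound 3 `Cc1ccccc1S(=O)(=O)c1cccc(N)c1C#N` carries a different core; how its core and that of compound 1 differ is not broken down here. In this assay compound 3 gives > 200000 nM, also a limit. Compound 4 `N#Cc1c(N)cccc1S(=O)(=O)c1ccccc1Br` has not yet been measured; it differs from compound 3 by bromo in place of methyl on an aromatic carbon. Among the compounds with values here, that is the same kind of change as the one from compound 1 to compound 2 but not the same one, since there the bromo sits para to a large group and here ortho to a large group. Given that the earlier step was a step that the two limits leave unreadable from compound 1 to compound 2 with both ends at the limit, the step is expected to be a number no higher from compound 3 to compound 4 (the limit leaves the size open). Compound 4 is accordingly estimated at 200000 nM, between 100000 nM and 400000 nM, and most likely will again be reported only as a limit.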

Compound 4, half-maximal inhibitory concentration: 40000 nM
Compound 4: the middle estimate sits 5.0-fold (0.70 log units) above what was measured, and the stated range ends above it.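

In this assay, bromo in place of methyl on an aromatic carbon, here ortho to a large group, gives an at least 5.0-fold lower number from compound 3 to compound 4 (0.69 log units; beyond the scatter), and compound 4 at 40000 nM is the only compound shown with a readable number. The same kind of change on the core of compound 1 cannot be read, because both ends of that step sit at a limit: the limit of > 200000 nM in this assay, at which 3 of the 4 values shown sit. The pair on the core of compound 3 therefore shows that this change can lower the number there, but it does not show whether the effect carries over from one core to the other, and the bromo also stands in a different place in the two pairs.

The compounds shown leave open whether the lower number of compound 4 is specific to bromo, since chloro, methoxy or an amine at the same place on the core of compound 3 does not appear among them. They also leave open how far below the limit compound 3 would fall if it could be read as a number.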